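Adding a fluorine to the outer phenyl ring

The compounds below may be only part of what the source reports. "The series", "measured", "known", "first", "only" and "open" are said of these compounds alone.

Of the compounds shown here, two sharing the same core have been measured in a functional assay on MCF7 cells (Homo sapiens) for cytotoxicity, read by MTT assay, with a stated time of 72 h; a lower number here means a stronger inhibitor, a higher number a weaker inhibitor. Compound 2, with the structure `O=C(Nc1ccc(Oc2ccnc3[nH]ccc23)c(F)c1)c1ccc(-c2ccccc2)cn1`, gives 4390 nM. Compound 1, with the structure `Cc1cccc(-c2ccnc(C(=O)Nc3ccc(Oc4ccnc5[nH]ccc45)cc3)c2)c1`, gives 7470 nM; the gap between compound 1 and compound 2 is within the usual scatter of this kind of measurement, so neither can be called the stronger of the two. The next compound, compound 3, has the structure `O=C(Nc1ccc(Oc2ccnc3[nH]ccc23)c(F)c1)c1ccc(-c2ccc(F)cc2)cn1`. It differs from compound 2 in one place: fluoro in place of hydrogen on an aromatic carbon, that is, a fluoro in place of hydrogen on an aromatic carbon. Going by the values given here, no measured pair in this small set shows what such a change does in this assay. Without such a precedent, the step is expected to be small, with no clear direction beyond the scatter: the estimated change from compound 2 to compound 3 is a 1.1-fold lower number from compound 2 to compound 3 (0.04 log units; within the scatter). Compound 3 is therefore expected to give about 4000 nM, within a range from 1500 nM to 12000 nM.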

Compound 3, half-maximal inhibitory concentration: > 10000 nM
Compound 3: a limit, no number (the forecaster's own chance of this, stated with the estimate: 0%); middle value at least 2.5-fold (0.39 log units) away from the limit.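

Going from phenyl to 4-fluorophenyl on the outer ring, with one fluoro in place of hydrogen, weakens the result in this assay, with an at least 2.2-fold higher number from compound 2 to compound 3 (0.35 log units; beyond the scatter). Compound 3 reaches only a limit of the assay and not a number, so the full size of this loss stays unknown: the limit of > 10000 nM in this assay, at which 1 of the 3 values shown sits.

Going by these compounds alone, compound 1 and compound 2 differ in more than one place, so this pair is the first to show that this position on the outer ring is sensitive to a change of one heavy atom.

From the compounds shown here alone, what a chlorine, a methoxy group or an amine would do at this position remains open, as does whether any group here would weaken the result. Nothing shown ties the loss to a particular property of the fluoro.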